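The compounds below may be only part of what the source reports. "The series", "measured", "known", "first", "only" and "open" are said of these compounds alone.

Measured in a functional assay on HCT-116 cells (Homo sapiens) for antiproliferative activity, read by MTT assay, with a stated time of 68 h; on this read-out higher numbers stand for weaker inhibition and lower numbers for stronger inhibition:
- Compound 1 `O=S(=O)(Nc1ccc(F)c(C#Cc2cnc3[nH]ncc3c2)c1F)c1ccccc1`: > 10000 nM, a limit
- Compound 2 `O=S(=O)(Nc1ccc(F)c(C#Cc2cnc3[nH]ncc3c2)c1F)c1ccccc1F`: > 10000 nM, a limit

Compound 2 has no number on this read-out, only a limit, and the same holds for compound 1: the limit of > 10000 nM in this assay, at which 2 of the 2 values shown sit. Compound 3 `O=S(=O)(Nc1ccc(F)c(C#Cc2cnc3[nH]ncc3c2)c1F)c1cccc(F)c1` has 3-fluorophenyl in place of 2-fluorophenyl on a sulfonyl sulfur. Going by the values given here, the only measured step that bears on this change is a step that the two limits leave unreadable from compound 1 to compound 2. That step put fluoro in place of hydrogen on an aromatic carbon, and it offers neither a size nor a direction to carry over. No step beyond the scatter is therefore expected in this assay, and compound 3 will most likely return a limit as well. The expected change is a step that the limit leaves unreadable from compound 2 to compound 3. Compound 3 is estimated at 12000 nM, with an expected range of 5000 nM to 30000 nM.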

Compound 3, half-maximal inhibitory concentration: > 10000 nM
Compound 3: a limit, no number (the forecaster's own chance of this, stated with the estimate: 80%); the middle value lies beyond the limit too.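

Compound 1, compound 2 and compound 3 all return a limit rather than a number in this assay, so no step among them can be read: the limit of > 10000 nM in this assay, at which 3 of the 3 values shown sit.

Left open is whether 2-fluorophenyl and 3-fluorophenyl on the sulfonyl sulfur differ at all, and whether any group there gives the shared core a measurable value.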